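A few compounds are considered here, and "the series" means these few. Any claim that something is new, unique, unknown or untested is made for them only; others in the source may bear on it.

Working notes on the series. Compound 3 `Fc1ccccc1Cn1nc(-c2ncc(F)c(N3CCCCC3)n2)cc1-c1ccon1` gives 490 uL/min in an ADME assay on microsomes from liver (Rattus norvegicus) for pharmacokinetics (a higher number here means faster removal of the compound, a lower number slower removal), and stands highest of the three measured numbers, though compound 1 `Fc1ccccc1Cn1nc(-c2ncc(F)c(OCC3CC3)n2)cc1-c1ccon1`, at 450 uL/min, lies within the scatter of it, a 1.1-fold higher number from compound 1 to compound 3 (0.04 log units; within the scatter). Compound 2 `CNc1nc(-c2cc(-c3ccon3)n(Cc3ccccc3F)n2)ncc1F` gives 160 uL/min, and the step of a 3.1-fold higher number from compound 2 to compound 3 (0.49 log units; beyond the scatter) is the only one beyond the scatter. Compound 4 `OC1CCCN(c2nc(-c3cc(-c4ccon4)n(Cc4ccccc4F)n3)ncc2F)C1` differs from compound 3 by hydroxy in place of hydrogen on a saturated ring carbon. Among the compounds with values here, no measured step adds hydroxy to a saturated ring; the steps at hand only swap the whole group on the aromatic carbon, as in a 2.8-fold lower number from compound 1 to compound 2 (0.45 log units; beyond the scatter). Within the data shown here, with no direct precedent, the expected step of a 1.4-fold lower number from compound 3 to compound 4 (0.15 log units; within the scatter) is no change beyond the scatter, leaning slightly lower. Compound 4 is therefore estimated at 350 uL/min, range 180 uL/min to 700 uL/min.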

Compound 4, intrinsic clearance in a liver preparation (reported as CLH), per the amount of preparation that the assay uses: 360 uL/min
Estimate against measurement, compound 4: 1.0-fold (0.01 log units) below; measured number inside the range.
By their numbers in this assay, from the lowest: compound 2; then compounds 4, 1 and 3 (each within the scatter of the next).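

In this assay, hydroxy on the saturated ring carbon of the piperidin-1-yl group leaves the number within the scatter (a 1.4-fold lower number from compound 3 to compound 4 (0.13 log units; within the scatter)). The 3-hydroxypiperidin-1-yl group also stays within the scatter of cyclopropylmethoxy (a 1.3-fold lower number from compound 1 to compound 4 (0.10 log units; within the scatter)), while methylamino remains beyond the scatter from it (a 2.3-fold higher number from compound 2 to compound 4 (0.35 log units; beyond the scatter)), so compound 2 alone stays lowest. Nothing available explains these numbers. As far as these compounds go, whether an amine or a carboxylic acid on this ring carbon would move the number beyond the scatter remains open, as does the effect of hydroxy on another ring carbon.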